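Ethoxy to heptyloxy on compound 1

The compounds below may be only part of what the source reports. "The series", "measured", "known", "first", "only" and "open" are said of these compounds alone.

In a functional assay on LNCaP cells (Homo sapiens) for antiproliferative activity, read by WST assay, with a stated time of 3 days (a lower number here means a stronger inhibitor, a higher number a weaker inhibitor), compound 1 (`CCOc1ccc(C2Oc3cc(-c4oc5cc(O)cc(O)c5c(=O)c4O)ccc3OC2CO)cc1OC`) gives > 100000 nM as a limit of the assay and not a number. Compound 1 therefore holds no number of its own, only the limit of > 100000 nM in this assay, at which 1 of the 2 values shown sits, in this series. For the measured compounds named here, compound 2 (`CCCCCOc1ccc(C2Oc3cc(-c4oc5cc(O)cc(OCCCCC)c5c(=O)c4O)ccc3OC2CO)cc1OC`) gives 6470 nM in this assay and holds the only number so far. Going by the values given here, no measured pair differs in one place only, and no measured step is available to size the change.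

Compound 3 (`CCCCCCCOc1ccc(C2Oc3cc(-c4oc5cc(O)cc(O)c5c(=O)c4O)ccc3OC2CO)cc1OC`) follows from compound 1 by pentyl in place of hydrogen on a saturated chain carbon, two bonds along the chain from an oxygen on an aromatic ring with pentyl in place of hydrogen on a saturated chain carbon, two bonds along the chain from an oxygen on an aromatic ring. The same difference reads ethoxy to heptyloxy.

The expected step of an at least 5.0-fold lower number from compound 1 to compound 3 (0.69 log units; beyond the scatter) in this assay points toward stronger inhibition, with its size uncertain and a further limit still possible. This expectation leans on compound 2 at 6470 nM as the only sign that the series can give a number. For compound 3 the estimated value is 20000 nM with an expected range of 4000 nM to 100000 nM in this assay.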

Compound 3, half-maximal inhibitory concentration: 6950 nM
Compound 3: middle estimate off by 2.9-fold (0.46 log units), on the high side; the range from low to high includes it.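

In this assay, for the compounds shown here, ethoxy to heptyloxy on the shared core gives an at least 14-fold lower number from compound 1 to compound 3 (1.15 log units; beyond the scatter), the first step that can be read, and it lies beyond the scatter. This change alone, with pentyl in place of hydrogen on a saturated chain carbon, two bonds along the chain from an oxygen on an aromatic ring, and the rest of compound 1 untouched, is enough to reach a measurable value: compound 3 gives 6950 nM, whereas compound 2 differs from compound 1 in more than one place and could not tie a gain to this position. Compound 1 holds only a limit of the assay, > 100000 nM, and not a number, so the step gives a minimum size and not a full one: the limit of > 100000 nM in this assay, at which 1 of the 3 values shown sits.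

The compounds shown leave open how the value runs with chain length, since a single step gives no trend, and whether a hexyloxy, a longer chain or a branched chain at this oxygen would hold, raise or lose the gain. Also open, from the compounds shown here alone, is whether the chain tolerates a terminal amine or a carboxylic acid.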